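Swapping cyano for cyclohexylmethyl on an ester chain

The compounds below may be only part of what the source reports. "The series", "measured", "known", "first", "only" and "open" are said of these compounds alone.

In an ADME assay on HepG2 2.2.15 cells (Homo sapiens) for cytotoxicity (on this read-out higher numbers stand for lower toxicity in this test and lower numbers for higher toxicity in this test), compound 3 `N#CCC(=O)OCCc1c(-c2ccccc2Cl)c2cc(Cl)ccc2[nH]c1=O` gives 100000 nM. Compound 1 `O=CCc1c(-c2ccccc2Cl)c2cc(Cl)ccc2[nH]c1=O` gives 120000 nM. Nothing separates those two values, as the shift reads a 1.2-fold lower number from compound 1 to compound 3 (0.08 log units; within the scatter). Compound 2 `CC(=O)OCCc1c(-c2ccccc2Cl)c2cc(Cl)ccc2[nH]c1=O` stands apart at 27000 nM, and the shift to it reads a 4.4-fold lower number from compound 1 to compound 2 (0.65 log units; beyond the scatter).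

Compound 4 `O=C(CCC1CCCCC1)OCCc1c(-c2ccccc2Cl)c2cc(Cl)ccc2[nH]c1=O` has cyclohexylmethyl in place of cyano on a saturated chain carbon bound to a carbonyl carbon. Among the compounds with values here, the only measured step at this place is a 3.7-fold higher number from compound 2 to compound 3 (0.57 log units; beyond the scatter), a modest one that adds cyano in place of hydrogen. Within the data shown here, compound 4 also lacks the cyano, so a modest drop in this assay is the natural expectation, although no measured compound carries cyclohexylmethyl and the size is uncertain. The expected change is a 4.0-fold lower number from compound 3 to compound 4 (0.60 log units; beyond the scatter), which lies beyond the scatter. Compound 4 is estimated at about 25000 nM, with an expected range from 7000 nM to 80000 nM.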

Compound 4, half-maximal cytotoxic concentration: 160000 nM
Compound 4: middle estimate off by 6.4-fold (0.81 log units), on the low side; measured number above the stated range.
By their numbers in this assay, from the lowest: compound 2; then compounds 3, 1 and 4 (each within the scatter of the next).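

In this assay, putting cyclohexylmethyl in place of cyano on the saturated chain carbon bound to a carbonyl carbon gives a 1.6-fold higher number from compound 3 to compound 4 (0.20 log units; within the scatter), so the nitrile is not required for the high number seen with compound 3. Against hydrogen at the same place, the step is a 5.9-fold higher number from compound 2 to compound 4 (0.77 log units; beyond the scatter), which runs the same way as a 3.7-fold higher number from compound 2 to compound 3 (0.57 log units; beyond the scatter), even though the two groups share neither size nor hydrogen-bond acceptor count. Nothing available explains why both groups differ from hydrogen in this way.

The compounds shown leave open whether a plain longer chain without a ring would behave like cyclohexylmethyl. They also leave open what an amine or a carboxylic acid at this place would do to the number.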